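The source may hold more compounds than are shown below. What is called first, only, known or untested is meant among the compounds shown, and "the series" means these compounds.

Compound 3 `ON=C(c1nc2ccccc2s1)c1nc2ccccc2s1`, compound 2 `Cc1cnc(/C(=N\O)c2nc3ccccc3s2)s1` and compound 1 `O/N=C/c1nc2ccccc2s1` share a common core carrying an oxime group. In an ADME assay on CHO cells (Cricetulus griseus) for cytotoxicity (on this read-out higher numbers stand for weaker inhibition and lower numbers for stronger inhibition), compound 2 gives 29000 nM. For compound 3 the result in this assay is only a limit, > 100000 nM. That limit is the limit of > 100000 nM in this assay, at which 1 of the 3 values shown sits. For compound 1 the entry in this assay reads "not determined" (no result reported), so no result was reported and compound 3 stands at the edge of what has been measured here. Compound 4 `CON=C(c1nc2ccccc2s1)c1nc2ccccc2s1` differs from compound 3 by a single change: methyl in place of hydrogen on an oxygen. Among the measured compounds shown here, no measured pair shows what this change does, so a step of a number no higher from compound 3 to compound 4 (the limit leaves the size open) is expected, which amounts to nothing beyond the usual scatter. Compound 4 is therefore estimated at 100000 nM, with a range from 30000 nM to 300000 nM.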

Compound 4, half-maximal inhibitory concentration: > 50000 nM
Compound 4 gave a limit, no number; the forecaster's own chance of this, stated with the estimate: 60%; the middle value lies beyond the limit too.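

Among the compounds shown here, compound 3 and compound 4 each give only a limit in this assay, so no step between them can be read. From the compounds shown here alone, what methyl in place of hydrogen on an oxygen does to this read-out stays open.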